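The source may report more compounds than this note shows. Statements on the series, on what has been measured and on what is new or still open speak of the compounds shown alone.

Compound 1 `COc1cc(Cl)ccc1C(=O)Nc1ccc(Br)cc1O`: 46600 nM
Compound 2 `COc1ccc(Cl)cc1C(=S)Nc1cc(Cl)ccc1O`: 8600 nM
Compound 3 `COc1ccc(Cl)cc1C(=S)Nc1cc(Cl)c(Cl)cc1O`: 3720 nM

All three were tested in a functional assay on HepG2 cells (Homo sapiens) for cytotoxicity, with a stated time of 24 h (a lower number here means a stronger inhibitor, a higher number a weaker inhibitor), where compound 2 holds the second highest of the three numbers, with compound 3 nearest and compound 1 furthest. Compound 4 `COc1ccc(Cl)cc1C(=S)Nc1cc(Br)ccc1O` has not yet been measured. Its change from compound 2 is bromo in place of chloro on an aromatic carbon, para to a hydroxy group. Among the measured compounds shown here, only one measured step bears on this, a 2.3-fold lower number from compound 2 to compound 3 (0.36 log units; beyond the scatter), a modest change with chloro in place of hydrogen. For the measured compounds named here, no measured step exchanges chloro for bromo, so only a small shift toward a lower number is expected, probably none beyond the scatter. The expected step is a 1.2-fold lower number from compound 2 to compound 4 (0.09 log units; within the scatter). For compound 4 the estimated value is 7000 nM, with an expected range of 3500 nM to 14000 nM.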

Compound 4, half-maximal inhibitory concentration: 8740 nM
Compound 4: the middle estimate sits 1.2-fold (0.10 log units) below what was measured, within the range that was stated.
By their numbers in this assay, from the lowest: compound 3; then compounds 2 and 4 (each within the scatter of the next); then compound 1.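

In this assay, bromo in place of chloro on this aromatic carbon, para to a hydroxy group, gives a 1.0-fold higher number from compound 2 to compound 4 (0.01 log units; within the scatter), so the two halogens cannot be told apart at this position. The earlier step, a 2.3-fold lower number from compound 2 to compound 3 (0.36 log units; beyond the scatter), showed only that adding chloro at another place on the ring could shift the number; this result shows that a halogen exchange at this carbon does not. Nothing available explains this outcome. From the compounds shown here alone, whether an amine, a methyl or a nitrile on this carbon would also leave the number within the scatter remains open.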